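The source may report more compounds than this note shows. Statements on the series, on what has been measured and on what is new or still open speak of the compounds shown alone.

Two compounds of the series have numbers in an assay on isolated protein for inhibition of Indoleamine 2,3-dioxygenase 1 (Homo sapiens); on this read-out higher numbers stand for weaker inhibition and lower numbers for stronger inhibition. Compound 1 `CC(=O)/C=C1\C(=O)Nc2ccc(Cl)cc21` gives 360 nM in this assay, and compound 2 `O=C1Nc2ccccc2/C1=N/c1ccccc1Br` gives 1240 nM. Of the two, compound 1 stands at the lower number, and its gap to compound 2 lies beyond the usual scatter of repeated measurements. For the measured compounds named here, the two structures differ in more than one place, so no single step between them can be read; only the two numbers themselves are known.

Compound 3 `CC(=O)CC(=O)/C=C1\C(=O)Nc2ccc(Cl)cc21` has not yet been measured in this assay. Relative to compound 1 the change is acetyl in place of hydrogen on a saturated chain carbon bound to a carbonyl carbon. The chain on the shared core is thus extended by an acetyl group, with the rest of compound 1 kept intact. Going by the values given here, no measured pair isolates a change of this kind, so there is no step from which to read its size. The expected step is a 1.5-fold higher number from compound 1 to compound 3 (0.18 log units; within the scatter), small and, if anything, toward a weaker number, with the chance that it falls within the scatter. Compound 3 is therefore estimated at 550 nM in this assay, with a range of 200 nM to 1600 nM.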

Compound 3, half-maximal inhibitory concentration: 190 nM
Compound 3: the middle estimate sits 2.9-fold (0.46 log units) above what was measured; measured number outside the range, below it.
By their numbers in this assay, from the lowest: compounds 3 and 1 (each within the scatter of the next); then compound 2.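

In this assay, for the compounds shown here, acetyl in place of hydrogen on a saturated chain carbon bound to a carbonyl carbon gives a 1.9-fold lower number from compound 1 to compound 3 (0.28 log units; within the scatter) and is the first single change that can be read. Cut one bond further out, the same difference reads as methyl to 2-oxopropyl, so this place on the chain of compound 1 accepts the added acetyl with no shift that stands clear of repeated-measurement scatter, in either direction. No supporting data bear on why the numbers of compound 1 and compound 3 lie so close.

This single pair cannot separate the effect of added chain length from that of the added carbonyl, and a plain propyl chain at the same place would help to tell them apart. Going by these compounds alone, whether the place also accepts a charged end group such as an amine or a carboxylic acid, or a longer chain than the one in compound 3, stays open, as does whether the acetyl step carries over to the core of compound 2.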